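Triazole substituent survey on a shared lactone core

A few compounds are considered here, and "the series" means these few. Any claim that something is new, unique, unknown or untested is made for them only; others in the source may bear on it.

Measured compounds:
compound 1, `O=C1O[C@H]([C@@H](O)Cn2cc(CNS(=O)(=O)c3ccc(Cl)cc3F)nn2)C(OCc2ccccc2)=C1OCc1ccccc1`, 20700 nM in a functional assay on HeLa cells (Homo sapiens) for antiproliferative activity, read by MTT assay, with a stated time of 72 h; a higher number here means a weaker inhibitor, a lower number a stronger inhibitor
compound 2, `C[Si](C)(C)c1cn(C[C@H](O)[C@H]2OC(=O)C(OCc3ccccc3)=C2OCc2ccccc2)nn1`, 22300 nM
compound 3, `O=C1O/C(=C\Cn2cc(-c3cc(C(F)(F)F)cc(C(F)(F)F)c3)nn2)C(OCc2ccccc2)=C1OCc1ccccc1`; for compound 3 this assay records only a limit, > 100000 nM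

Compound 2 gives one of the two actual numbers in this assay, and compound 1 sits within the usual scatter of it, so the two cannot be told apart. Compound 3, which carries a different linker to the core as well as a different ring on the triazole, does not return a number at all, only a limit.

Compound 4, `CCCCCc1ccc(-c2cn(C[C@H](O)[C@H]3OC(=O)C(OCc4ccccc4)=C3OCc3ccccc3)nn2)cc1`, is not yet measured. It differs from compound 2 in one place: a group of 11 heavy atoms (11 carbon; one six-membered aromatic ring of carbon only) in place of a group of 4 heavy atoms (3 carbon, 1 silicon; no ring), on an aromatic carbon. Among the compounds with values here, no measured pair in this set isolates such a change, so there is no step to lean on. The expectation is for a step from compound 2 to compound 4 of a 1.3-fold higher number from compound 2 to compound 4 (0.10 log units; within the scatter), that is, little change beyond the scatter, with the risk that the assay again reports only a limit as it does for compound 3. Compound 4 is therefore estimated at 28000 nM, within 9000 nM to 90000 nM.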

Compound 4, half-maximal inhibitory concentration: 8390 nM
Beside the measured number, compound 4's estimate is 3.3-fold (0.52 log units) above it; the whole stated range lies above it.
By their numbers in this assay, from the lowest: compound 4; then compounds 1 and 2 (each within the scatter of the next). At a limit, above all of these: compound 3.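

In this assay, within the data shown here, the aromatic carbon of the five-membered aromatic ring with 3 nitrogen accepts a far larger group than the one in compound 2: 4-pentylphenyl in place of the silicon-bearing group gives a 2.7-fold lower number from compound 2 to compound 4 (0.42 log units; beyond the scatter), a modest step beyond the scatter. Among these compounds, this is the only single-place step in the set, and it shows that the added ring and pentyl chain at this position do not cost activity and instead give a modest gain. No measurement shown bears on why the step occurs.

Among the compounds shown here, the single step cannot show whether the ring or the pentyl chain carries the change. On these data alone, it also remains open how a plain phenyl, a shorter or longer chain on that ring, or an amine or carboxylic acid at the end of the chain would read in this assay.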